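This account rests on a few compounds, and the source may have more. Where it says the series, first, only, none or still open, it means among the compounds named here.

Measured in a physicochemical assay for solubility, read by LC-MS, in phosphate buffer, with a stated time of 24 h, at pH 7.4; on this read-out lower numbers stand for lower solubility and higher numbers for higher solubility:
- compound 1 `C[C@@H]1CC(=O)N(c2cnc(NCc3c(F)ccc4c3CCO4)n3cnnc23)C1`: 130000 nM
- compound 2 `CN(C(=O)c1ccccc1)c1cnc(NCc2c(F)ccc3c2CCO3)n2cnnc12`: 280000 nM

Within the data shown here, compound 2 holds the higher of these two numbers, and compound 1 is the only comparison available. Next is compound 3 `O=C1CCCN1c1cnc(NCc2c(F)ccc3c2CCO3)n2cnnc12`, not yet measured. The change is 2-oxopyrrolidin-1-yl in place of benzoyl(methyl)amino on an aromatic carbon.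

Among the measured compounds shown here, one measured step bears on this: a 2.2-fold higher number from compound 1 to compound 2 (0.33 log units; beyond the scatter). That step is modest but beyond the scatter. It installs benzoyl(methyl)amino at the same place, replacing 4-methyl-2-oxopyrrolidin-1-yl, so the change to compound 3 runs roughly in reverse. For the measured compounds named here, no measured compound carries the lactam without its 4-methyl group, so this reading rests on a single pair. A modest move to a lower number in this assay is therefore expected, and the estimated step is a 1.9-fold lower number from compound 2 to compound 3 (0.27 log units; within the scatter). For compound 3 the estimate is 150000 nM, with an expected range of 70000 nM to 320000 nM.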

Compound 3, solubility: 640000 nM
The estimate for compound 3 lay 4.3-fold (0.63 log units) below the measured number; the measured number lies above the stated range.
By their numbers in this assay, from the lowest: compound 1; then compound 2; then compound 3.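

At the aromatic carbon of the six-membered ring, exchange with benzoyl(methyl)amino does not run one way for both lactams: this assay shows a 2.3-fold higher number from compound 2 to compound 3 (0.36 log units; beyond the scatter) for 2-oxopyrrolidin-1-yl, while 4-methyl-2-oxopyrrolidin-1-yl lies on the other side of compound 2, as a 2.2-fold higher number from compound 1 to compound 2 (0.33 log units; beyond the scatter) shows. Within the lactam pair, hydrogen in place of methyl on the saturated ring carbon gives a 4.9-fold higher number from compound 1 to compound 3 (0.69 log units; beyond the scatter) in this assay and so places the two lactams on opposite sides of compound 2. No measurement at hand accounts for either step.

Open, as far as these compounds go, is whether a hydroxyl or a longer chain on that saturated ring carbon would fall nearer compound 1 or compound 3. Also open, from the compounds shown here alone, is where a six-membered lactam or an open-chain amide would stand at the aromatic carbon.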